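Replacing the amide of compound 1 with a sulfonamide

The compounds below may be only part of what the source reports. "The series", "measured", "known", "first", "only" and "open" are said of these compounds alone.

The two measured compounds share one core and differ only in the group on the amide nitrogen. Compound 1 `CCCN(CC[C@H]1CC[C@H](NC(=O)/C=C/c2ccc(Cl)cc2)CC1)[C@H]1CCc2nc(N)sc2C1` carries a 2-(4-chlorophenyl)ethenyl group on its carbonyl carbon, and in an assay on brain for displacement of a labelled ligand from D(3) dopamine receptor (Rattus norvegicus) (a higher number here means a weaker inhibitor, a lower number a stronger inhibitor), compound 1 gives 2.5 nM. Compound 2 `CCCN(CC[C@H]1CC[C@H](NC(=O)c2cccc3ncccc23)CC1)[C@H]1CCc2nc(N)sc2C1` has quinolin-5-yl there instead, and in this assay compound 2 gives 1.6 nM. The step of a 1.6-fold lower number from compound 1 to compound 2 (0.19 log units; within the scatter) shows that exchanging the aryl part on the carbonyl leaves the number essentially where it was. Compound 1 therefore stands highest of the two numbers, yet its gap to compound 2 is no more than the assay's own scatter.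

Compound 3 `CCCN(CC[C@H]1CC[C@H](NS(=O)(=O)c2ccccc2)CC1)[C@H]1CCc2nc(N)sc2C1` is unmeasured. It differs from compound 1 as follows: phenylsulfonyl in place of (2-(4-chlorophenyl)ethenyl)carbonyl on an amine nitrogen. Within the data shown here, no measured step touches the carbonyl itself; the single step seen concerns the group beyond it and is small. Compound 3 is therefore expected to be measured at 15 nM, with a range of 4 nM to 60 nM, so that the estimated step of a 6.0-fold higher number from compound 1 to compound 3 (0.78 log units; beyond the scatter) points toward a weaker inhibitor.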

Compound 3, inhibition constant: 0.79 nM
Compound 3: middle estimate off by 19-fold (1.28 log units), on the high side; the whole stated range lies above it.
By their numbers in this assay, from the lowest: compound 3; then compounds 2 and 1 (each within the scatter of the next).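

The earlier step altered only the group beyond the carbonyl, whereas this one replaces the carbonyl itself, and in this assay the change to phenylsulfonyl on the amine nitrogen gives a 3.2-fold lower number from compound 1 to compound 3 (0.50 log units; beyond the scatter). The carbonyl is therefore not needed for a low number at this place, and a sulfonyl link, carrying a plain phenyl ring without the chlorine or the ethenyl part, does at least as well here. However, the link and the group beyond it change together in this single step, so the modest gain cannot be assigned to either alone, and no evidence on the reason for it is at hand.

The compounds shown leave open how much of the step belongs to the sulfonyl and how much to the loss of the 2-(4-chlorophenyl)ethenyl part, a question that a benzoyl group on the same nitrogen would help to separate. As far as these compounds go, how far the sulfonyl link tolerates other groups also remains open, for example a methyl group, a 4-chlorophenyl ring or a quinolin-5-yl ring on the sulfur.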